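The source may report more compounds than this note shows. Statements on the series, on what has been measured and on what is new or still open speak of the compounds shown alone.

Compound 2 `Nc1cc(N)c2nc(-c3ccccc3)c(Oc3ccc(F)cc3)nc2c1` carries a 4-fluorophenoxy group on the shared core. In a functional assay on NCI-H226 cells (Homo sapiens) for inhibition, read by sulforhodamine B assay, with a stated time of 48 h (a higher number here means a weaker inhibitor of growth, a lower number a stronger inhibitor of growth), compound 2 gives 20400 nM. Compound 1 `Nc1cc(N)c2nc(-c3ccccc3)c(Sc3ccc(F)cc3)nc2c1` gives 19100 nM in this assay, and a 1.1-fold higher number from compound 1 to compound 2 (0.03 log units; within the scatter). Of the two plain numbers, compound 2 holds the highest, with compound 1 nearest and within the scatter. Compound 3 `CCOC(=O)[C@H](CCC(=O)O)NC(=O)c1ccc(CNc2nc3cc(N)cc(N)c3nc2-c2ccccc2)cc1` gives in this assay only a limit, < 100000 nM. Compound 4 `Nc1cc(N)c2nc(-c3ccccc3)c(NCc3ccc(F)cc3)nc2c1` differs from compound 2 in one place: (4-fluorobenzyl)amino in place of 4-fluorophenoxy on an aromatic carbon. Among the measured compounds shown here, the only measured step on this aromatic carbon, the exchange of sulfur-linked for oxygen-linked 4-fluorophenyl, stayed within the scatter, so no step beyond the scatter is expected here either. Compound 4 is expected to give about 16000 nM, between 5000 nM and 50000 nM, an expected step of a 1.3-fold lower number from compound 2 to compound 4 (0.11 log units; within the scatter).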

Compound 4, concentration for 50% growth inhibition: 22400 nM
Estimate against measurement, compound 4: 1.4-fold (0.15 log units) below; the range from low to high includes it.
By their numbers in this assay, from the lowest: compounds 1, 2 and 4 (each within the scatter of the next).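

Replacing 4-fluorophenoxy with (4-fluorobenzyl)amino adds a hydrogen-bond donor on this aromatic carbon, yet this assay shows a 1.1-fold higher number from compound 2 to compound 4 (0.04 log units; within the scatter). Set against the (4-fluorophenyl)sulfanyl group, the same group gives a 1.2-fold higher number from compound 1 to compound 4 (0.07 log units; within the scatter), so all three groups on this carbon now lie within the scatter of each other, including one with a nitrogen link and a donor. Nothing measured here bears on why these numbers stay together. From the compounds shown here alone, it remains open whether a plain amine or a carboxylic acid on this carbon, without the 4-fluorophenyl ring, would move the number beyond the scatter.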